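The source may hold more compounds than are shown below. What is called first, only, known or untested is meant among the compounds shown, and "the series" means these compounds.

In a functional assay on HL-60 cells (Homo sapiens) for antiproliferative activity, with a stated time of 72 h (on this read-out higher numbers stand for weaker inhibition and lower numbers for stronger inhibition), compound 1 (`OC[C@H]1O[C@@H](n2cnc3c(NCc4ccccc4F)ncnc32)[C@H](O)[C@@H]1O`) gives 3200 nM, compound 2 (`OC[C@H]1O[C@@H](n2cnc3c(NCc4ccc(Cl)cc4Cl)ncnc32)[C@H](O)[C@@H]1O`) gives 96300 nM and compound 3 (`OC[C@H]1O[C@@H](n2cnc3c(NCc4ccc(F)c(Cl)c4)ncnc32)[C@H](O)[C@@H]1O`) gives 3500 nM. Compound 3 therefore sits level with compound 1, as a 1.1-fold higher number from compound 1 to compound 3 (0.04 log units; within the scatter) is within the scatter, and far under compound 2, with a 28-fold lower number from compound 2 to compound 3 (1.44 log units; beyond the scatter) being large.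

Next is compound 4 (`Cc1ccc(O)c(CNc2ncnc3c2ncn3[C@@H]2O[C@H](CO)[C@@H](O)[C@H]2O)c1`), which shares the core: 2-hydroxy-5-methylphenyl in place of 3-chloro-4-fluorophenyl on a saturated chain carbon bound to a nitrogen on an aromatic ring. Here 2-hydroxy-5-methylphenyl stands in place of 3-chloro-4-fluorophenyl on a saturated chain carbon bound to a nitrogen on an aromatic ring.

All measured steps alter this same group, but none brings in 2-hydroxy-5-methylphenyl, so they offer only a rough guide. Two of the three compounds are level, and compound 2 goes against that flatness, with a 30-fold higher number from compound 1 to compound 2 (1.48 log units; beyond the scatter) being large. The expected step is a 1.7-fold higher number from compound 3 to compound 4 (0.23 log units; within the scatter), which would stay within the scatter. The high side of the range is kept wide because of a 30-fold higher number from compound 1 to compound 2 (1.48 log units; beyond the scatter). For compound 4 the estimated value is 6000 nM, with an expected range of 1500 nM to 40000 nM.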

Compound 4, half-maximal inhibitory concentration: 15000 nM
Compound 4: middle estimate off by 2.5-fold (0.40 log units), on the low side; low and high end bracket the measured number.
By their numbers in this assay, from the lowest: compounds 1 and 3 (each within the scatter of the next); then compound 4; then compound 2.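

At this place, on a saturated chain carbon bound to a nitrogen on an aromatic ring, 2-hydroxy-5-methylphenyl fills the gap between the earlier level pair and the distant compound 2 in this assay: a 4.3-fold higher number from compound 3 to compound 4 (0.63 log units; beyond the scatter), a 4.7-fold higher number from compound 1 to compound 4 (0.67 log units; beyond the scatter) and a 6.4-fold lower number from compound 2 to compound 4 (0.81 log units; beyond the scatter) are all modest. Halogen alone does not order the four compounds: halogen-free compound 4 lies above halogen-bearing compounds 1 and 3, yet below halogen-bearing compound 2. No supporting measurement accounts for these steps.

From the compounds shown here alone, compound 4 brings in hydroxy and methyl together, so the share of each in these steps remains open; a phenyl carrying only one of the two would separate them. Going by these compounds, how an amine or a carboxylic acid on the phenyl ring would read at this place also remains open.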